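This account rests on a few compounds, and the source may have more. Where it says the series, first, only, none or still open, it means among the compounds named here.

Going by the values given here, in a functional assay on SK-MEL-28 cells (Homo sapiens) for cytotoxicity, read by MTT assay (on this read-out lower numbers stand for stronger inhibition and higher numbers for weaker inhibition), compound 3 `O=S(=O)(NCCCNc1nccc(-c2c(-c3cccc(F)c3)nc3sccn23)n1)c1ccc(Cl)cc1` gives 8450 nM, which is the second highest of the three numbers so far, sitting within the scatter of compound 2 `O=S(=O)(NCCNc1nccc(-c2c(-c3cccc(F)c3)nc3sccn23)n1)c1ccc(F)cc1` at 9450 nM and of compound 1 `O=S(=O)(NCCCNc1nccc(-c2c(-c3cccc(F)c3)nc3sccn23)n1)c1ccccc1` at 6850 nM. Compound 4 `O=C(NCCNc1nccc(-c2c(-c3cccc(F)c3)nc3sccn23)n1)c1c(F)cccc1F` differs from compound 3 by ((2,6-difluorophenyl)carbonyl)amino in place of (((4-chlorophenyl)sulfonyl)amino)methyl on a saturated chain carbon, two bonds along the chain from a nitrogen on an aromatic ring. Among the compounds with values here, no measured step swaps a sulfonyl for a carbonyl, so only the neighbouring changes guide: a 1.1-fold lower number from compound 2 to compound 3 (0.05 log units; within the scatter), and a 1.4-fold higher number from compound 1 to compound 2 (0.14 log units; within the scatter), both within the scatter, as was a 1.2-fold higher number from compound 1 to compound 3 (0.09 log units; within the scatter). With the shared core unchanged, compound 4 is expected to land near compound 3, at a 1.1-fold lower number from compound 3 to compound 4 (0.05 log units; within the scatter). Compound 4 is therefore estimated at 7500 nM, with a range from 2500 nM to 25000 nM.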

Compound 4, half-maximal inhibitory concentration: 11400 nM
Compound 4: middle estimate off by 1.5-fold (0.18 log units), on the low side, and the stated range covers the measured number.
By their numbers in this assay, from the lowest: compounds 1, 3, 2 and 4 (each within the scatter of the next).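

With this assay, the carbonyl link is now seen at this position, and the number stays within the scatter of all three sulfonyl compounds, with a 1.2-fold higher number from compound 2 to compound 4 (0.08 log units; within the scatter), a 1.3-fold higher number from compound 3 to compound 4 (0.13 log units; within the scatter) and a 1.7-fold higher number from compound 1 to compound 4 (0.22 log units; within the scatter). So, among these compounds, exchanging the sulfonyl for a carbonyl, together with the new ring fluorines, brings no clear change. Nothing available explains this flat picture. The effects of the carbonyl and the fluorines cannot be separated here. Going by these compounds, whether an amine, a carboxylic acid or a longer chain at this position would shift the number also stays open.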